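Compound 3 against the isoquinolin-3-yl of compound 2

The source may hold more compounds than are shown below. What is called first, only, known or untested is meant among the compounds shown, and "the series" means these compounds.

Going by the values given here, in an ADME assay on microsomes from liver (Rattus norvegicus) for metabolic stability, read by LC-MS, with a stated time of 10 min, tested at 0.5 uM (on this read-out lower numbers stand for a less stable compound and higher numbers for a more stable compound), compound 2 `c1cnc2c(c1)CCC[C@@H]2N(CCCN1CCNCC1)Cc1cc2ccccc2cn1` gives 59%, the lower of the two numbers so far, and compound 1 `c1ccc2c(c1)CN[C@@H](CN(CCCN1CCNCC1)[C@H]1CCCc3cccnc31)C2` gives 100%. Compound 3 `c1cnc2c(c1)CN[C@H](CN(CCCN1CCNCC1)[C@H]1CCCc3cccnc31)C2` is still unmeasured. Its difference from compound 2 is a group of 10 heavy atoms (8 carbon, 2 nitrogen; one six-membered non-aromatic ring with 1 hetero atom, one six-membered aromatic ring with 1 hetero atom) in place of a group of 10 heavy atoms (9 carbon, 1 nitrogen; one six-membered aromatic ring of carbon only, one six-membered aromatic ring with 1 hetero atom), on a saturated chain carbon bound to an amine nitrogen. Among the compounds with values here, the one measured step that bears on this is a number 41 percentage points lower from compound 1 to compound 2 (beyond the scatter), which is large and beyond the scatter. That step put isoquinolin-3-yl in place of 1,2,3,4-tetrahydroisoquinolin-3-yl on a saturated chain carbon bound to an amine nitrogen. Within the data shown here, compound 3 also loses isoquinolin-3-yl and gains a six-membered non-aromatic ring with 1 hetero atom, but its group is not the one in compound 1, so a large upward step of somewhat smaller size is expected: a number 29 percentage points higher from compound 2 to compound 3 (beyond the scatter). Compound 3 is estimated at 88%, within a range of 70% to 100%.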

Compound 3, percent of the compound remaining: 87%
Compound 3: the middle estimate sits 1 percentage points above what was measured; the measured number falls inside the stated range.
By their numbers in this assay, from the lowest: compound 2; then compound 3; then compound 1.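

In this assay, the upward move at this place is not tied to 1,2,3,4-tetrahydroisoquinolin-3-yl alone: a second group with one six-membered non-aromatic ring in place of isoquinolin-3-yl gives a number 28 percentage points higher from compound 2 to compound 3 (beyond the scatter). The two groups with a non-aromatic ring are still not equivalent, as exchanging one for the other gives a number 13 percentage points lower from compound 1 to compound 3 (beyond the scatter). No measurement bears on why the number moves with either exchange.

With only these three compounds, the effect of the non-aromatic ring cannot be separated from that of the aromatic ring with 1 hetero atom or of the defined stereocentre in the entering group. As far as these compounds go, it also remains open how a carboxylic acid or a longer chain would read on a saturated chain carbon bound to an amine nitrogen.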